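A few compounds are considered here, and "the series" means these few. Any claim that something is new, unique, unknown or untested is made for them only; others in the source may bear on it.

Measured so far in an ADME assay on microsomes from liver (Mus musculus) for metabolic stability; on this read-out lower numbers stand for slow clearance and higher numbers for fast clearance:
- Compound 1 `CC(C(=O)O)c1nn(Cc2cn3cc(OCC4CC4)c(Cl)cc3n2)c2ccccc2c1=O`: 80 mL/min/kg
- Compound 2 `C[C@@H](C(=O)O)c1nn(Cc2cn3cc(OCC4CC4)c(Cl)cc3n2)c2ccccc2c1=O`: < 55 mL/min/kg (a limit, not a number)
- Compound 3 `CCC(C(=O)O)c1nn(Cc2cn3cc(OCC4CC4)c(Cl)cc3n2)c2ccccc2c1=O`: < 56.7 mL/min/kg (a limit, not a number)

Compound 3 has no exact value, only the limit < 56.7 mL/min/kg. Set against the other limit, it gives a step that the two limits leave unreadable from compound 2 to compound 3, so the two cannot be put in order.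

Compound 4 `C[C@H](C(=O)O)c1nn(Cc2cn3cc(OCC4CC4)c(Cl)cc3n2)c2ccccc2c1=O` carries 1-carboxyethyl in place of 1-carboxypropyl on an aromatic carbon. Going by the values given here, the entering group brings one defined stereocentre, drawn the opposite way to the one in compound 2.

Among the compounds with values here, two measured steps bear on this change. One is an at least 1.4-fold lower number from compound 1 to compound 3 (0.14 log units; that floor lies within the scatter), and the other is an at least 1.4-fold lower number from compound 1 to compound 2 (0.16 log units; that floor lies within the scatter), where the difference is the fact that one of compounds 1 and 2 is drawn with a defined configuration and the other without, at the place where they differ. Both are floors that lie within the scatter, so neither shows a firm drop.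

Within the data shown here, compound 4 has the same atoms and bonds as compound 1, which gives 80 mL/min/kg, the only true number here. A value near that number is therefore expected, although a limit like the one for the opposite drawing remains possible. The expected change is upward, as an at least 1.4-fold higher number from compound 3 to compound 4 (0.17 log units; that floor lies within the scatter). For compound 4 the estimated clearance is 85 mL/min/kg, with an expected range from 55 mL/min/kg to 125 mL/min/kg.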

Compound 4, clearance: < 53.4 mL/min/kg
Compound 4 gave a limit, no number; the forecaster's own chance of this, stated with the estimate: 20%; middle value at least 1.5-fold (0.20 log units) away from the limit.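

In this assay compound 4 gives only a limit of < 53.4 mL/min/kg and no number, so the opposite drawing of the stereocentre in the 1-carboxyethyl group also ends as a limit. Going by these compounds alone, the only readable step is an at least 1.4-fold lower number from compound 1 to compound 4 (0.17 log units; that floor lies within the scatter) and it is a floor, so it shows no firm drop; the steps from compound 2 and from compound 3 to compound 4 cannot be read, with limits on both sides of each. Compound 2 and compound 4 cannot be put in order, so nothing here shows that the drawn configuration at this carbon matters for clearance, and only one thing separates the two: the fact that compounds 2 and 4 differ only in the configuration as drawn.

Going by these compounds, how far the true values of compound 2, compound 3 and compound 4 lie under their limits stays open, and so does any real difference between the two drawn forms. Also open, on these data alone, is how this position would respond to a longer chain such as 1-carboxybutyl, or to a primary amide in place of the carboxylic acid.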